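The source may report more compounds than this note shows. Statements on the series, on what has been measured and on what is new or still open speak of the compounds shown alone.

Compound 1 `CN(C)c1noc(-c2cccc(CN(C)c3ccc4[nH]nc(C(=O)O)c4c3)c2O)n1`: 2440 mL/min/kg
Compound 2 `CC(C)c1noc(-c2cccc(CNc3ccc4[nH]nc(C(=O)O)c4c3)c2O)n1`: 5440 mL/min/kg

Both values come from an ADME assay on the whole organism (plasma, Mus musculus, strain CD1) for metabolic stability, with a stated time of 8 h, at a dose of 0.3 mg/kg by the intravenous route; a higher number here means faster removal of the compound, a lower number slower removal. Of the two, compound 2 has the higher number, and its gap to compound 1 lies beyond the usual scatter. Compound 3 `Cc1nc(-c2cccc(CNc3ccc4[nH]nc(C(=O)O)c4c3)c2O)sc1C` differs from compound 2 in one group: 4,5-dimethyl-1,3-thiazol-2-yl in place of 3-isopropyl-1,2,4-oxadiazol-5-yl on an aromatic carbon. Among the compounds with values here, no measured pair shows a change of this kind, so the guide is weak, and only a small downward move, within the scatter, is expected. The estimated change is a 1.4-fold lower number from compound 2 to compound 3 (0.13 log units; within the scatter). For compound 3 the estimate is 4000 mL/min/kg, with an expected range from 1800 mL/min/kg to 8000 mL/min/kg.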

Compound 3, clearance: 4500 mL/min/kg
Estimate against measurement, compound 3: 1.1-fold (0.05 log units) below; the range from low to high includes it.
By their numbers in this assay, from the lowest: compounds 1, 3 and 2 (each within the scatter of the next, the first and the last beyond it).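

In this assay, the group on the aromatic carbon ortho to a hydroxy group was exchanged, 4,5-dimethyl-1,3-thiazol-2-yl in place of 3-isopropyl-1,2,4-oxadiazol-5-yl, with a 1.2-fold lower number from compound 2 to compound 3 (0.08 log units; within the scatter). At this position, then, one five-membered aromatic ring can replace the other with no clear difference in how quickly the compound is removed. No measurement at hand explains this result.

From the compounds shown here alone, it remains open whether a group of another kind here, such as an amide or a phenyl ring, would move the number beyond the scatter.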